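This account rests on a few compounds, and the source may have more. Where it says the series, first, only, none or still open, it means among the compounds named here.

Going by the values given here, compound 2 `CN1CCN(CCNCc2cn(-c3ccc(F)cc3F)nc2-c2ccc(OC(F)(F)F)cc2)CC1` is the only member of the series with a number in an ADME assay on Huh-7 cells (Homo sapiens) for cytotoxicity; on this read-out lower numbers stand for higher toxicity in this test and higher numbers for lower toxicity in this test; in this assay compound 2 gives 18000 nM. Compound 1 `Cc1ccccc1CNc1nn(-c2ccc(F)cc2F)cc1CNCCN1CCN(C)CC1` contributes the second value shown. In this assay compound 1 reports only a limit, > 20000 nM. The step of an at least 1.1-fold lower number from compound 1 to compound 2 (0.04 log units; that floor lies within the scatter) rests on that limit and lies within the scatter, so the two compounds cannot be ordered; the limit of > 20000 nM in this assay, at which 1 of the 2 values shown sits, is the ceiling the test reports.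

Compound 3 `CN1CCN(CCNCc2cn(-c3ccc(F)cc3F)nc2-c2ccccc2)CC1` is the next entry to be measured in this assay. It differs from compound 2 by hydrogen in place of trifluoromethoxy on an aromatic carbon. Among the compounds with values here, only one measured step exists for comparison, the exchange that led from compound 1 to compound 2, and it showed nothing beyond the scatter while touching a different part of the molecule. The shared core with its difluorophenyl, the methylpiperazine chain and the amine linker stay unchanged. With both measured compounds sitting at the upper end of the test, the removal of the trifluoromethoxy group is expected to give a 1.1-fold higher number from compound 2 to compound 3 (0.05 log units; within the scatter), no step beyond the scatter. Compound 3 is therefore estimated at 20000 nM, with a range of 9000 nM to 40000 nM, and a substantial chance that the assay again reports only a limit.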

Compound 3, half-maximal cytotoxic concentration: > 20000 nM
Compound 3: no number, only a limit (the forecaster's own chance of this, stated with the estimate: 50%); the middle value sits exactly at the limit.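

In this assay compound 3 reports only a limit, > 20000 nM. Exchanging trifluoromethoxy for hydrogen on the aromatic carbon gives an at least 1.1-fold higher number from compound 2 to compound 3 (0.04 log units; that floor lies within the scatter), so compound 2 and compound 3 cannot be ordered, and the phenyl without this group also reaches the limit of the test. The step between compound 1 and compound 3 cannot be read, and the read-out of the series now stands as follows: the limit of > 20000 nM in this assay, at which 2 of the 3 values shown sit.

On these data alone, it remains open whether any group at this position, such as a carboxylic acid, a nitrile or a dimethylamino group, would give a number clearly lower than those seen so far. The methylpiperazine chain and the difluorophenyl stay the same in all three compounds, so the compounds shown also leave open what a shorter chain, a morpholine in place of the methylpiperazine or a chlorine in place of a fluorine would do in this assay.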